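The source may report more compounds than this note shows. Statements on the series, on what has been measured and on what is new or still open speak of the compounds shown alone.

Measured so far in a functional assay on SK-BR-3 cells (Homo sapiens) for antiproliferative activity; on this read-out higher numbers stand for weaker inhibition and lower numbers for stronger inhibition:
compound 1 `Cc1c(OC2CCN(C)CC2)ccc2cc(NC(=O)c3ccccc3)c(=O)oc12`: 11500 nM
compound 2 `CC(=O)Oc1ccc(C(=O)Nc2cc3ccc(OC4CCN(C)CC4)c(C)c3oc2=O)cc1Cl`: 3500 nM

On these numbers compound 2 stands lowest of the two. Going by the values given here, the only step measured so far, a 3.3-fold lower number from compound 1 to compound 2 (0.52 log units; beyond the scatter), concerns 4-acetoxy-3-chlorophenyl in place of phenyl on a carbonyl carbon. Compound 3 `Cc1c(OC2CCN(C)CC2)ccc2cc(NC(=O)c3ccc(O)c(Cl)c3)c(=O)oc12` keeps the shared core of compound 2 and differs from it in one place: hydrogen in place of acetyl on an oxygen on an aromatic ring. Among the compounds with values here, no measured step covers this change on its own; the step of a 3.3-fold lower number from compound 1 to compound 2 (0.52 log units; beyond the scatter) exchanged the whole aryl group at once, so it does not separate what the acetyl contributes from what the rest of that group contributes. The expectation for compound 3 in this assay is therefore for little movement, with any step from compound 2 likely within the scatter or at most modestly beyond it. The estimated step is a 1.4-fold lower number from compound 2 to compound 3 (0.15 log units; within the scatter). Compound 3 is estimated at 2500 nM, with a range from 700 nM to 9000 nM.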

Compound 3, half-maximal inhibitory concentration: 2300 nM
Compound 3: the middle estimate sits 1.1-fold (0.04 log units) above what was measured; low and high end bracket the measured number.
By their numbers in this assay, from the lowest: compounds 3 and 2 (each within the scatter of the next); then compound 1.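

In this assay, hydrogen in place of acetyl on the oxygen gives a 1.5-fold lower number from compound 2 to compound 3 (0.18 log units; within the scatter), so acetoxy and hydroxy cannot be told apart here. Against phenyl on the carbonyl carbon, 3-chloro-4-hydroxyphenyl gives a 5.0-fold lower number from compound 1 to compound 3 (0.70 log units; beyond the scatter), which shows that the step beyond the scatter does not depend on the acetyl being present. Nothing available explains either step.

Chloro and hydroxy entered together in both aryl exchanges, so the share each contributes to the step from phenyl remains unresolved. Also open, on these data alone, is how a methoxy or an amino group would read in place of the hydroxy, and whether a carboxylic acid there would keep the number of compound 3 or move it beyond the scatter.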